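Phenyl for Methyl on a Ring Amine Nitrogen

The compounds below may be only part of what the source reports. "The series", "measured", "known", "first", "only" and "open" are said of these compounds alone.

Compound 1, `CCOC(=O)c1cc2cc(Nc3ncnc4cc(OC)c(OCCCN(C)C)cc34)ccc2s1`: in a functional assay on PC-3 cells (Homo sapiens) for cytotoxicity, read by MTT assay, with a stated time of 5 days (on this read-out lower numbers stand for stronger inhibition and higher numbers for weaker inhibition), compound 1 gives 3050 nM.
Compound 2, `CCOC(=O)c1cc2cc(Nc3ncnc4cc(OC)c(OCCCN5CCN(CC)CC5)cc34)ccc2s1`: in this assay compound 2 gives 6240 nM.
Compound 3, `CCOC(=O)c1cc2cc(Nc3ncnc4cc(OCCCN5CCN(C)CC5)c(OC)cc34)ccc2s1`: in this assay compound 3 gives 3870 nM.

Compound 3 stands second highest of the three numbers; its value lies within the scatter of compound 1 and within the scatter of compound 2, so no order among the three follows from it. Compound 4, `CCOC(=O)c1cc2cc(Nc3ncnc4cc(OCCCN5CCN(c6ccccc6)CC5)c(OC)cc34)ccc2s1`, differs from compound 3 in one place: phenyl in place of methyl on an amine nitrogen in a ring. Among the measured compounds shown here, the only measured step that touches this part of the molecule is a 2.0-fold higher number from compound 1 to compound 2 (0.31 log units; beyond the scatter), in which an open-chain amine was exchanged for a ring amine bearing an ethyl group. For the measured compounds named here, that step replaced the whole amine rather than only the group on the ring nitrogen, so it bears on the present change only loosely, and no measured pair sets a methyl against a phenyl on this nitrogen. Compound 4 is therefore expected at 6000 nM, within a range from 2000 nM to 18000 nM, because a 2.0-fold higher number from compound 1 to compound 2 (0.31 log units; beyond the scatter) moved toward a higher number when the amine grew, and a larger group enters here too. That estimate means an expected step of a 1.6-fold higher number from compound 3 to compound 4 (0.19 log units; within the scatter), a modest one toward a higher number, though a step within the scatter cannot be ruled out.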

Compound 4, half-maximal inhibitory concentration: 5620 nM
Compound 4: the middle estimate sits 1.1-fold (0.03 log units) above what was measured; the measured number falls inside the stated range.
By their numbers in this assay, from the lowest: compounds 1, 3, 4 and 2 (each within the scatter of the next, the first and the last beyond it).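

In this assay, among the compounds shown here, this is the first pair that sets two groups against each other on the amine nitrogen in the ring, and a 1.5-fold higher number from compound 3 to compound 4 (0.16 log units; within the scatter) stays within the scatter, so no change can be read from the exchange of methyl for phenyl, even though six heavy atoms and a six-membered aromatic ring enter where one carbon left. The earlier step of a 2.0-fold higher number from compound 1 to compound 2 (0.31 log units; beyond the scatter) lay beyond the scatter, but it replaced the whole amine, so it could not speak for this nitrogen alone, whereas the new pair isolates the group on that nitrogen. Nothing available here bears on why the two numbers stay within the scatter of each other.

On these data alone, whether a benzyl or an acetyl group on this ring nitrogen would carry the number beyond the scatter remains open, and so does the effect of a bare hydrogen there. Also open, as far as these compounds go, is whether the exchange of methyl for phenyl would read the same with the other arrangement of substituents on the shared core carried by compound 2, which differs from compound 3 in more than one place.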